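A few compounds are considered here, and "the series" means these few. Any claim that something is new, unique, unknown or untested is made for them only; others in the source may bear on it.

For the measured compounds named here, in a functional assay on B16 cells (Mus musculus) for cytotoxicity, read by CCK-8 assay, with a stated time of 24 h (a lower number here means a stronger inhibitor, a higher number a weaker inhibitor), three compounds sharing one core have numbers so far. Compound 3 `COc1ccc(-c2nc(N)c(Oc3ccccc3OC)c(OCCO)n2)cc1` gives 18100 nM, and compound 1 `COc1cccc(-c2nc(N)c(Oc3ccccc3OC)c(Cl)n2)c1`, at 23600 nM, lies within the usual scatter of it. Compound 2 `COc1ccc(-c2nc(N)c(Oc3ccccc3OC)c(Cl)n2)cc1` gives 47800 nM, and swapping its chloro for 2-hydroxyethoxy produced a modest step, a 2.6-fold lower number from compound 2 to compound 3 (0.42 log units; beyond the scatter). Compound 4 `COc1ccccc1Oc1c(N)nc(-c2cccc(Br)c2)nc1OCCO` keeps that 2-hydroxyethoxy group but carries 3-bromophenyl in place of 4-methoxyphenyl on an aromatic carbon. Going by the values given here, no measured compound contains bromine, so the nearest guide is the modest step of a 2.0-fold higher number from compound 1 to compound 2 (0.31 log units; beyond the scatter), where 4-methoxyphenyl replaced 3-methoxyphenyl. In this assay, a slightly lower number is therefore expected, not clearly beyond the scatter: a 1.4-fold lower number from compound 3 to compound 4 (0.14 log units; within the scatter). For compound 4 the estimate is 13000 nM, with an expected range of 6000 nM to 30000 nM.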

Compound 4, half-maximal inhibitory concentration: 21900 nM
Compound 4: middle estimate off by 1.7-fold (0.23 log units), on the low side; the measured number falls inside the stated range.
By their numbers in this assay, from the lowest: compounds 3, 4 and 1 (each within the scatter of the next); then compound 2.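

In this assay, replacing 4-methoxyphenyl with 3-bromophenyl gives a 1.2-fold higher number from compound 3 to compound 4 (0.08 log units; within the scatter) and so leaves no readable difference. For the compounds shown here, the earlier compounds compared only two methoxyphenyl groups at this position, so this is the first sign that a bromine-bearing ring can stand there, at least alongside the 2-hydroxyethoxy group. Nothing available explains this result. Still open, going by these compounds, is whether a ring carrying an amine or a carboxylic acid at this position would separate from these numbers. Also open, on these data alone, is whether 3-bromophenyl would behave alike with chloro in place of 2-hydroxyethoxy.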